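A few compounds are considered here, and "the series" means these few. Any claim that something is new, unique, unknown or untested is made for them only; others in the source may bear on it.

Measured in a functional assay on PC-3 cells (Homo sapiens), read by fluorescence and BrdU incorporation, with a stated time of 48 h, tested at 10 uM; on this read-out lower numbers stand for a stronger effect and higher numbers for a weaker effect at the one concentration tested:

- compound 1 `COc1cc(OC)c(C(=O)/C=C/c2ccccc2SC)c(OC)c1` gives 30%
- compound 2 `COc1cccc(/C=C/C(=O)c2c(OC)cc(OC)cc2OC)c1` gives 23%
- compound 3 `COc1cc(O)c(C(=O)/C=C/c2ccccc2SC)c(OC)c1` gives 35%

Compound 4 `COc1cccc(/C=C/C(=O)c2c(O)cc(OC)cc2OC)c1` has not yet been measured in this assay.

The two cores differ as follows: 3-methoxyphenyl in place of 2-(methylsulfanyl)phenyl on a double-bonded chain carbon bound to a double-bonded chain carbon. On this read-out the step is a number 7 percentage points lower from compound 1 to compound 2 (within the scatter), so compound 1 and compound 2 cannot be separated here. Compound 2 and compound 3 are not linked by a single change; their numbers differ by more than the usual scatter, with compound 2 giving the lower one.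

Within the core of compound 1 a single change has been measured: hydrogen in place of methyl on an oxygen on an aromatic ring. The step is a number 5 percentage points higher from compound 1 to compound 3 (within the scatter). The same change is now to be made within the core of compound 2: hydrogen in place of methyl on an oxygen on an aromatic ring. The place is the same word for word in both cases, so this is the same change, only on the other core. With one measured instance of the change, and that instance within the scatter, no trend can be claimed from it.

For the measured compounds named here, from compound 2 to compound 4 in this assay the step is expected to be a number 5 percentage points higher from compound 2 to compound 4 (within the scatter), resting on a number 5 percentage points higher from compound 1 to compound 3 (within the scatter) as the only measured instance of the change. For compound 4 in this assay the expected value is therefore 28%, with a range of 15% to 42%.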

Compound 4, a percentage reported as activity, at one concentration (the size of the read-out at that concentration, not a potency): 39%
For compound 4 the middle estimate is 11 percentage points below the measured one; the range from low to high includes it.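

On the core of compound 2, hydrogen in place of methyl on an oxygen on an aromatic ring, the methoxy to hydroxy change, gives in this assay a number 16 percentage points higher from compound 2 to compound 4 (beyond the scatter). Set beside the earlier instance, the two steps cannot be told apart: the same change on two cores in this assay, a number 5 percentage points higher (within the scatter) from compound 1 to compound 3 and a number 16 percentage points higher (beyond the scatter) from compound 2 to compound 4, 11 percentage points apart, within the scatter of two such steps The change can therefore be carried from one core to the other without any sign of a core-dependent difference, but this does not fix a common size for it, since only two instances exist and only the one on the core of compound 2 lies beyond the scatter.

The compounds shown leave open how a longer chain such as ethyl on that oxygen, or an amine in place of the hydroxy, would read in this assay. Also open, as far as these compounds go, is whether the step recurs on cores carrying a group such as a carboxylic acid in place of 3-methoxyphenyl or 2-(methylsulfanyl)phenyl, and, with a single concentration read, whether the effect would be stronger or weaker at any other concentration.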